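Replacing an Ester Ethyl with Hydrogen in a Paw-Swelling Test

A few compounds are considered here, and "the series" means these few. Any claim that something is new, unique, unknown or untested is made for them only; others in the source may bear on it.

Compound 1, `CC(C)OC(=O)C(=O)Nc1cccccc1=O`, gives 63% in a functional assay on the whole organism (strain Sprague-Dawley CD) for inhibition, with Rattus norvegicus as the target, read by paw edema, at a dose of 30 mg/kg by the oral route; a higher number here means a stronger effect of the compound at the dose given, a lower number a weaker effect.
Compound 2, `CCOC(=O)COC(=O)C(=O)Nc1cccccc1=O`, gives 31% in this assay.

Going by the values given here, of the two compounds measured so far, compound 2 stands lowest; its nearest neighbour is compound 1, separated by a number 32 percentage points lower from compound 1 to compound 2 (beyond the scatter). That step swapped isopropyl for (ethoxycarbonyl)methyl on an oxygen next to a carbonyl group, and it cost a great deal of inhibition.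

Compound 3, `O=C(O)COC(=O)C(=O)Nc1cccccc1=O`, differs from compound 2 in one place: hydrogen in place of ethyl on an oxygen next to a carbonyl group. Read one bond further out, this turns ethoxycarbonyl into carboxy, so the side-chain ester becomes the free acid.

Among the compounds with values here, no measured step matches this change. Within the data shown here, the only step available, from compound 1 to compound 2, concerns a different group in a different spot and shows that large swings are possible here, but it gives no direction for trading an ethyl ester for an acid. With nothing to push either way, the step for compound 3 is expected to be about a number 1 percentage points lower from compound 2 to compound 3 (within the scatter), within the scatter. Compound 3 is therefore estimated at 30%, with a range from 10% to 50%.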

Compound 3, a percentage reported as inhibition, in the whole organism at one dose (the size of the read-out at that dose, not a potency): 45%
Beside the measured number, compound 3's estimate is 15 percentage points below it, within the range that was stated.
By their numbers in this assay, from the lowest: compound 2; then compound 3; then compound 1.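

Hydrogen in place of ethyl gives a number 14 percentage points higher from compound 2 to compound 3 (beyond the scatter) in this assay, so the end of this side chain matters: carboxy and ethoxycarbonyl, though attached through the same oxygen next to a carbonyl group, do not read the same. Carboxymethyl in place of isopropyl still gives a number 18 percentage points lower from compound 1 to compound 3 (beyond the scatter), so among these three compounds the free acid recovers only part of the ground lost with (ethoxycarbonyl)methyl, and isopropyl remains the best of the groups shown at this place. Nothing at hand explains why these groups rank in this order, and the numbers alone describe the outcome in the whole animal at a single dose, not the reason for it.

The compounds shown leave open whether a different end group on the same short chain, such as an amine or a primary amide, would fall nearer compound 2 or nearer compound 1. They also leave open how a longer chain ending in carboxy, or a small plain group such as ethyl or tert-butyl in place of isopropyl, would read at this place.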